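A few compounds are considered here, and "the series" means these few. Any claim that something is new, unique, unknown or untested is made for them only; others in the source may bear on it.

In a functional assay on 786-0 cells (Homo sapiens) for inhibition, read by spectrophotometry and sulforhodamine B assay, with a stated time of 48 h (a higher number here means a weaker inhibitor of growth, a lower number a stronger inhibitor of growth), compound 1 `O=C1CS/C(=N/N=C/c2c[nH]c3ccccc23)N1c1cccc2ccccc12` gives 62100 nM, and compound 2 `S=C(N/N=C/c1c[nH]c2ccc(Br)cc12)Nc1cccc2ccccc12` gives 6560 nM. Compound 1 therefore holds the higher of the two numbers, with a gap beyond the usual scatter, which makes it the weaker growth inhibitor of this pair.

Compound 3 `O=C1CS/C(=N/N=C/c2c[nH]c3ccc(Br)cc23)N1c1cccc2ccccc12` is compound 1 with a single change: bromo in place of hydrogen on an aromatic carbon. This puts bromo in place of hydrogen on an aromatic carbon, on a six-membered aromatic ring of carbon only that is part of a fused system of two rings.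

For the measured compounds named here, no two measured compounds differ in one place only, so the data offer no direct measure of this change. Compound 2 also carries bromo and gives 6560 nM, but it differs from compound 1 elsewhere too, so it is only a loose guide. On that guide, a moderate move toward stronger growth inhibition is expected in this assay, though a step within the scatter remains possible. The expected change is a 2.5-fold lower number from compound 1 to compound 3 (0.40 log units; beyond the scatter). For compound 3 the estimated value is 25000 nM, with an expected range from 7000 nM to 70000 nM.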

Compound 3, concentration for 50% growth inhibition: 29100 nM
Compound 3: the middle estimate sits 1.2-fold (0.07 log units) below what was measured, and the stated range covers the measured number.
By their numbers in this assay, from the lowest: compound 2; then compound 3; then compound 1.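

In this assay, for the compounds shown here, the swap of hydrogen for bromo gives a 2.1-fold lower number from compound 1 to compound 3 (0.33 log units; beyond the scatter) and so, for the first time, the effect of one change can be read on its own. The step is modest but beyond the scatter, which shows that this aromatic carbon, on the six-membered aromatic ring of carbon only within the fused system of two rings, can carry bromo with a gain rather than a loss in growth inhibition; compound 1 and compound 2 could not show this, as they differ in more than one place. No measurement at hand explains the step, so it stands as an observation only.

From the compounds shown here alone, it remains open whether this gain is particular to bromo or would also come with another group on the same aromatic carbon, such as chloro, methoxy or an amine. Going by these compounds, it is also open whether bromo would give a similar step on a different carbon of the same ring, or on the same carbon with a different group in place of the naphthyl-bearing part of the core.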